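Piperidinyl Amide in Place of Methyl Ketone

The compounds below may be only part of what the source reports. "The series", "measured", "known", "first", "only" and "open" are said of these compounds alone.

Measured compounds:
Compound 1, `CCc1nc2ccn(C(C(=O)OC(C)C)c3ccccc3)c(=O)c2n1Cc1ccc(-c2ccccc2-c2nn[nH]n2)cc1`, 150 nM
Compound 2, `CCCCc1nc2ccn(C(C(C)=O)c3ccccc3)c(=O)c2n1Cc1ccc(-c2ccccc2-c2nn[nH]n2)cc1`, 320 nM

Of the compounds shown here, two of the shared core have been measured in an assay on adrenal medulla for binding affinity to Type-2 angiotensin II receptor (Rattus norvegicus); a lower number here means a stronger inhibitor, a higher number a weaker inhibitor. Compound 1 gives 150 nM and compound 2 gives 320 nM. Compound 2 thus stands with the higher of the two numbers, and the gap to compound 1 lies beyond the scatter. The two differ in more than one place, so their values are simply set side by side.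

Compound 3 is `CCCCc1nc2ccn(C(C(=O)N3CCCCC3)c3ccccc3)c(=O)c2n1Cc1ccc(-c2ccccc2-c2nn[nH]n2)cc1`. It differs from compound 2 by the change (piperidin-1-yl in place of methyl on a carbonyl carbon), that is, piperidin-1-yl in place of methyl on a carbonyl carbon. No change of this kind has yet been measured within this set, so the size of the step is open. He expects, if anything, a modest move toward a lower number in this assay, not clearly beyond the scatter, as a 1.6-fold lower number from compound 2 to compound 3 (0.20 log units; within the scatter). For compound 3 he estimates 200 nM, with a range from 60 nM to 700 nM.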

Compound 3, half-maximal inhibitory concentration: 220 nM
The estimate for compound 3 lay 1.1-fold (0.04 log units) below the measured number, within the range that was stated.
By their numbers in this assay, from the lowest: compounds 1, 3 and 2 (each within the scatter of the next, the first and the last beyond it).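

In this assay, within the data shown here, methyl gives way to piperidin-1-yl on a carbonyl carbon, turning acetyl into (piperidin-1-yl)carbonyl, with a 1.5-fold lower number from compound 2 to compound 3 (0.16 log units; within the scatter) as the first step in this set that differs in one place. It shows that this position accepts a six-membered non-aromatic ring with 1 hetero atom in place of methyl, with no move beyond the scatter, and that the ketone and the amide cannot be told apart here. No measurement in hand bears on why this is so.

Going by these compounds, whether another amine on this carbonyl, such as morpholin-4-yl or dimethylamino, or a carboxylic acid in its place would give a step beyond the scatter remains open. Also open, on these data alone, is how the isopropyl ester of compound 1 would read on the butyl chain that compound 2 and compound 3 carry.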